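The source may report more compounds than this note shows. Statements on the series, on what has been measured and on what is new or still open speak of the compounds shown alone.

Compound 1 `CCCC(C)Oc1cccc2ccc(N)nc12`: 105 nM
Compound 2 `CC(CC(C)(C)C)Oc1cccc2ccc(N3CCCCC3)nc12`: > 2000 nM

For the measured compounds named here, in an assay on cells with melanin-concentrating hormone receptor 1 (Homo sapiens) as the target, read by radioligand binding (on this read-out higher numbers stand for weaker inhibition and lower numbers for stronger inhibition), compound 1 gives 105 nM, the only plain number in this set. Compound 2 is reported only as a limit of the assay, > 2000 nM, so no number is known for it. Compound 3 `CCC#CCOc1cccc2ccc(N)nc12` is not yet measured; it differs from compound 1 in one place: pent-2-yn-1-yl in place of 1-methylbutyl on an oxygen on an aromatic ring. Going by the values given here, no measured pair differs in a single place, so the size of this step cannot be read from the data; a step within the scatter, or a small loss, is expected, as a 1.4-fold higher number from compound 1 to compound 3 (0.15 log units; within the scatter). Compound 3 is therefore expected to give about 150 nM in this assay, between 40 nM and 600 nM.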

Compound 3, half-maximal inhibitory concentration: > 2000 nM
Compound 3 gave a limit, no number (the forecaster's own chance of this, stated with the estimate: 10%); at least 13-fold (1.12 log units) between middle value and limit.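

Swapping 1-methylbutyl for pent-2-yn-1-yl on this oxygen keeps 5 carbon atoms, yet in this assay it brings an at least 19-fold higher number from compound 1 to compound 3 (1.27 log units; beyond the scatter). This position is therefore sensitive to the shape of the group, not only to its carbon count. The reading for compound 3 is a limit of the assay, so the full size of the step stays unknown: the limit of > 2000 nM in this assay, at which 2 of the 3 values shown sit.

These compounds cannot show whether the triple bond or the loss of the methyl branch matters more. A straight pentyl chain on the same oxygen would separate the two.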